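The source may hold more compounds than are shown below. What is called first, only, known or untested is meant among the compounds shown, and "the series" means these compounds.

Measured in a functional assay on DU-145 cells (Homo sapiens) for cytotoxicity, read by trypan blue exclusion, with a stated time of 96 h; on this read-out higher numbers stand for weaker inhibition and lower numbers for stronger inhibition:
Compound 1 `COc1cc(OC)c(/C=C/S(=O)(=O)Nc2ccc(OC)c(O)c2)c(OC)c1`: 30 nM
Compound 2 `COc1ccc(NS(=O)(=O)/C=C/c2c(OC)cc(OCCCC(=O)O)cc2OC)cc1O`: 10000 nM

Compound 1 holds the lower of these two numbers, which makes it the stronger inhibitor of the pair. Compound 3 `COC(=O)C(C)Nc1cc(NS(=O)(=O)/C=C/c2c(OC)cc(OC)cc2OC)ccc1OC` has not been measured yet. It keeps the core of compound 1 but carries (1-(methoxycarbonyl)ethyl)amino in place of hydroxy on an aromatic carbon, ortho to a methoxy group: (1-(methoxycarbonyl)ethyl)amino in place of hydroxy on an aromatic carbon.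

Among the measured compounds shown here, only one measured step can guide an expectation, and only loosely. In it, 2-carboxyethyl replaces a hydrogen on a saturated chain carbon bound to an oxygen on an aromatic ring, giving a 330-fold higher number from compound 1 to compound 2 (2.52 log units; beyond the scatter). That is a different group at a different place, so its size cannot simply be carried over. Still, it is the only record of a chain being added to this core, and the number rose sharply. In this assay a rise is therefore expected here too, probably a smaller one and with wide uncertainty. The expected change is a 10-fold higher number from compound 1 to compound 3 (1.00 log units; beyond the scatter). For compound 3 the estimated value is 300 nM, with an expected range from 40 nM to 2500 nM.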

Compound 3, half-maximal inhibitory concentration: 100 nM
Compound 3: the middle estimate sits 3.0-fold (0.48 log units) above what was measured; the range from low to high includes it.
By their numbers in this assay, from the lowest: compound 1; then compound 3; then compound 2.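

Among the compounds shown here, this is the first look at the hydroxy position itself: in this assay, (1-(methoxycarbonyl)ethyl)amino in place of hydroxy gives a 3.3-fold higher number from compound 1 to compound 3 (0.52 log units; beyond the scatter), a modest step that lies beyond the scatter. The hydroxy group, 1 heavy atom, can therefore give way to a branched group of 7 heavy atoms with only a modest change, and compound 3 still gives 100 nM, so this position accepts a far larger group without a large rise in the number. Nothing available here explains why the step has this size.

This single change replaces the hydroxy group and brings in a nitrogen link, a branching methyl and a methyl ester all at once, so the share of each in the rise cannot be separated. A plain amine at this position would help to separate them, and so would a carboxylic acid in place of the methyl ester or a longer chain in place of the branched one.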